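The source may report more compounds than this note shows. Statements on the series, on what has been measured and on what is new or still open speak of the compounds shown alone.

Working notes on the series. In a functional assay on A549 cells (Homo sapiens) for antiproliferative activity, read by MTT assay, with a stated time of 48 h (on this read-out lower numbers stand for stronger inhibition and higher numbers for weaker inhibition), compound 1 `C/C(=C\CC/C(C)=C/CC[C@@H]1[C@@]2(C)CCC(=O)C(C)(C)[C@H]2CC[C@@]1(C)O)CC/C=C(\C)C(=O)OCc1cn(-c2cccc(Cl)c2)nn1` gives 147000 nM, the highest of the two numbers in hand. Among the measured compounds shown here, compound 2 `C/C(=C\CC/C(C)=C/CC[C@@H]1[C@@]2(C)CCC(=O)C(C)(C)[C@H]2CC[C@@]1(C)O)CC/C=C(\C)C(=O)OCc1cn(C[C@@H]2O[C@H](n3ccc(=O)[nH]c3=O)C[C@H]2O)nn1` gives 28100 nM in this assay, a lower number that lies beyond the usual scatter; no single-point step links these two compounds, so the comparison says only what the two values show. Compound 3 `C/C(=C\CC/C(C)=C/CC[C@@H]1[C@@]2(C)CCC(=O)C(C)(C)[C@H]2CC[C@@]1(C)O)CC/C=C(\C)C(=O)OCc1cn(-c2ccccc2Br)nn1` is not yet measured. It differs from compound 1 in one place: 2-bromophenyl in place of 3-chlorophenyl on an aromatic nitrogen. The shared core is unchanged, and the 1-(3-chlorophenyl)-1H-1,2,3-triazol-4-yl group becomes 1-(2-bromophenyl)-1H-1,2,3-triazol-4-yl. For the measured compounds named here, no measured pair isolates a change of this kind, so the step expected in this assay is small, in either direction, and likely within the scatter. The step from compound 1 to compound 3 that is estimated here is a 1.2-fold lower number from compound 1 to compound 3 (0.09 log units; within the scatter). Compound 3 is therefore expected to give about 120000 nM in this assay, within a range from 40000 nM to 360000 nM.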

Compound 3, half-maximal inhibitory concentration: > 150000 nM
Compound 3 ended at the assay's limit; the forecaster's own chance of this, stated with the estimate: 20%; at least 1.2-fold (0.09 log units) between middle value and limit.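

In this assay, compound 3 sits at a limit of the assay and not at a number: the limit of > 150000 nM in this assay, at which 1 of the 3 values shown sits.

Putting 2-bromophenyl in place of 3-chlorophenyl on the aromatic nitrogen gives an at least 1.0-fold higher number from compound 1 to compound 3 (0.00 log units; that floor lies within the scatter). That is a floor and not a size, so the true step may be negligible or much larger. Among the compounds shown here, this is the first step that changes only this one place, and it shows that the change does not bring the number down.

The halogen and its place on the phenyl ring change together in this step, and the compounds shown do not separate the two. From the compounds shown here alone, it also stays open how an amine or a carboxylic acid on that phenyl ring would read in this assay.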